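Cyclopropyl-oxazole arylsulfonamides: growth inhibition in a leukaemia line

The compounds below may be only part of what the source reports. "The series", "measured", "known", "first", "only" and "open" are said of these compounds alone.

Measured compounds:
- compound 1 `O=S(=O)(Nc1ccc(Br)c(Cl)c1)c1ccc(-c2cnc(C3CC3)o2)cc1`: 70300 nM
- compound 2 `Cc1ccc(NS(=O)(=O)c2ccc(-c3cnc(C4CC4)o3)cc2)cc1C`: > 100000 nM
- compound 3 `Cc1cc(Cl)ccc1NS(=O)(=O)c1ccc(-c2cnc(C3CC3)o2)cc1`: 54700 nM

The series shares one core and varies only the aryl group on the sulfonamide nitrogen. In a functional assay on cells (leukaemia cell line, Homo sapiens) for inhibition, read by sulforhodamine B assay, with a stated time of 48 h (on this read-out lower numbers stand for stronger inhibition of growth and higher numbers for weaker inhibition of growth), compound 1 gives 70300 nM and stands at the higher of the two numbers shown, with compound 3 nearest. Compound 2 reaches only the limit (the limit of > 100000 nM in this assay, at which 1 of the 3 values shown sits), so it has no number. Compound 3 gives 54700 nM in this assay.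

The steps observed are small: a 1.3-fold lower number from compound 1 to compound 3 (0.11 log units; within the scatter), an at least 1.4-fold higher number from compound 1 to compound 2 (0.15 log units; that floor lies within the scatter), and an at least 1.8-fold lower number from compound 2 to compound 3 (0.26 log units; that floor lies within the scatter). None of them rises clearly above the scatter.

Compound 4 `Cc1cc(F)cc(NS(=O)(=O)c2ccc(-c3cnc(C4CC4)o3)cc2)c1` has not yet been measured. It differs from compound 1 as follows: 3-fluoro-5-methylphenyl in place of 4-bromo-3-chlorophenyl on a sulfonamide nitrogen. The step from compound 1 to compound 2 is the closest comparison, since both halogens leave there too, and it ended at a limit; the step from compound 1 to compound 3, which keeps one halogen, stayed within the scatter. Compound 4 is therefore expected to sit at or somewhat above compound 1, with a fair chance of a limit; the expected step is a 1.4-fold higher number from compound 1 to compound 4 (0.13 log units; within the scatter). Compound 4 is estimated at 95000 nM, within a range of 45000 nM to 200000 nM.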

Compound 4, concentration for total growth inhibition: 7250 nM
For compound 4 the middle estimate is 13-fold (1.12 log units) above the measured one, outside the stated range (below it).
By their numbers in this assay, from the lowest: compound 4; then compounds 3 and 1 (each within the scatter of the next). At a limit, above all of these: compound 2.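

Among these compounds, at this position, on a sulfonamide nitrogen, 3-fluoro-5-methylphenyl is the first aryl group to give steps beyond the scatter in this assay (a 9.7-fold lower number from compound 1 to compound 4 (0.99 log units; beyond the scatter), and a 7.5-fold lower number from compound 3 to compound 4 (0.88 log units; beyond the scatter)). Loss of bromine and chlorine alone does not account for the shift: compound 2 carries neither, yet the change to the fluorine-bearing aryl group of compound 4 still gives a clear step (an at least 13-fold lower number from compound 2 to compound 4 (1.13 log units; beyond the scatter)), while the groups exchanged between compound 1 and compound 4 match in heavy-atom, donor and acceptor counts and in net charge, so those counts do not separate them. Compound 2 stands at a limit, so its step gives only a floor: the limit of > 100000 nM in this assay, at which 1 of the 4 values shown sits.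

The compounds shown do not separate the identity of the ring substituents from their placement, since no two of them carry the same pair of groups arranged differently, so it stays unclear whether the fluorine, the methyl or the arrangement goes with the lower number. Also open, from the compounds shown here alone, is whether the lower number holds with a methoxy group or an amine in place of the fluorine of compound 4.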